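Three chromone styryl analogues at the assay limit

The source may report more compounds than this note shows. Statements on the series, on what has been measured and on what is new or still open speak of the compounds shown alone.

Measured compounds:
compound 1 `COc1ccc2oc(/C=C/c3ccc(OC(F)(F)F)cc3)cc(=O)c2c1` gives > 40000 nM in a functional assay on PC-3 cells (Homo sapiens) for antiproliferative activity, read by MTT assay, with a stated time of 12 h; a lower number here means a stronger inhibitor, a higher number a weaker inhibitor
compound 2 `COc1cc(OC)c2c(=O)cc(/C=C/c3ccc(OCC4CC4)cc3)oc2c1` gives > 40000 nM in this assay
compound 3 `COc1cccc2oc(/C=C/c3ccc(OC(F)(F)F)cc3)cc(=O)c12` gives > 40000 nM in this assay

All three values shown here are limits of the assay rather than numbers. Compound 2 stands at such a limit, and so it cannot be placed above or below the other two; the only thing that can be said of the set is that (the limit of > 40000 nM in this assay, at which 3 of the 3 values shown sit). Going by the values given here, no single-change step between measured compounds exists among them, so no measured step size is available.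

Compound 4 `COc1cc(OC)c2c(=O)cc(/C=C/c3ccc(C(F)(F)F)cc3)oc2c1` is the compound still to be measured. It differs from compound 2 in one place: trifluoromethyl in place of cyclopropylmethoxy on an aromatic carbon, which is trifluoromethyl in place of cyclopropylmethoxy on an aromatic carbon, para to a large group. Since compound 2 itself sits at the limit, there is no scatter-referenced number from which a step could be counted, and the expectation for the step from compound 2 to compound 4 is therefore none beyond the scatter, the most probable outcome being that this assay again reports only a limit for compound 4. The estimated step that the limit leaves unreadable from compound 2 to compound 4 is expected to be essentially flat. Compound 4 is expected to give about 50000 nM, within a range from 20000 nM to 200000 nM, with the measured value likely to emerge as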

Compound 4, half-maximal inhibitory concentration: > 40000 nM
Compound 4 gave a limit, no number; the forecaster's own chance of this, stated with the estimate: 80%; the middle value is on the limit's open side.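

In this assay compound 4 gives > 40000 nM, which is a limit and not a number. Compound 2 also stands at a limit, so the step between compound 2 and compound 4 cannot be read. The compounds shown leave open how strongly any of them inhibits, and whether trifluoromethyl in place of cyclopropylmethoxy alters that: the limit of > 40000 nM in this assay, at which 4 of the 4 values shown sit.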